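This account rests on a few compounds, and the source may have more. Where it says the series, first, only, none or still open, it means among the compounds named here.

Measured compounds:
- compound 1, `NC(=O)c1cn(-c2ccc(O)cc2C(F)(F)F)c2cc(-c3ccncc3)ccc2c1=O`: 20000 nM in an assay on isolated protein for inhibition of Calpain-1 catalytic subunit (Homo sapiens); a higher number here means a weaker inhibitor, a lower number a stronger inhibitor
- compound 2, `NC(=O)c1cn(-c2ccc(O)cc2Cl)c2cc(-c3ccoc3)ccc2c1=O`: 2000 nM in this assay

Compound 2 has the lowest number of the two, and its nearest neighbour is compound 1, whose number is higher by a gap that lies beyond the usual scatter. The two compounds differ at more than one place, so nothing can be pinned on a single change between them; the two values alone show that compound 2 is the stronger inhibitor of the pair in this assay.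

Compound 3, `NC(=O)c1cn(-c2ccc(O)cc2Cl)c2cc(-c3cccnn3)ccc2c1=O`, has not yet been measured. It differs from compound 2 in one place: pyridazin-3-yl in place of furan-3-yl on an aromatic carbon. For the measured compounds named here, no measured pair shows what such a swap does in this assay, so the direction of the step is open. A step of modest size is expected, with a weaker inhibitor about as likely as an equal one, so for compound 3 the expected step is a 2.0-fold higher number from compound 2 to compound 3 (0.30 log units; within the scatter). The estimate for compound 3 in this assay is 4000 nM, with a range from 1000 nM to 16000 nM.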

Compound 3, half-maximal inhibitory concentration: 2000 nM
Beside the measured number, compound 3's estimate is 2.0-fold (0.30 log units) above it; measured number inside the range.
By their numbers in this assay, from the lowest: compounds 2 and 3 (each within the scatter of the next); then compound 1.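

In this assay, putting pyridazin-3-yl in place of furan-3-yl on this aromatic carbon gives no change at the digits printed from compound 2 to compound 3 (within the scatter) when the rest of the structure stays the same. This is the only pair shown that differs in one place, and it shows that this position can carry either a five-membered aromatic ring with one hetero atom or a six-membered aromatic ring with two hetero atoms without any readable shift in the number. Nothing measured here bears on why these two groups give matching values.

On these data alone, compound 1 differs from both compound 2 and compound 3 in more than one place, so its steps to them cannot be read, and the separate contributions of its trifluoromethyl group and its pyridin-4-yl group remain unknown. As far as these compounds go, it also remains open whether this position would give a similar number with a group that is not an aromatic ring, such as an amine, a carboxylic acid or a longer chain.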